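A few compounds are considered here, and "the series" means these few. Any claim that something is new, unique, unknown or untested is made for them only; others in the source may bear on it.

Of the compounds shown here, three from one quinolone-type series have been measured in a functional assay on Hep 3B2 cells (Homo sapiens) for antiproliferative activity, read by MTT assay, with a stated time of 24 h, tested at 0.05 ug/mL; on this read-out higher numbers stand for a stronger effect at the one concentration tested and lower numbers for a weaker effect. Compound 1 `CCc1ccc2nc(C(=O)Nc3c(F)cc(-c4cccc(F)c4)cc3F)c(C)c(O)c2c1` gives 5.62% in this assay. Compound 2 `COc1ccc2nc(C(=O)Nc3ccc(-c4ccccc4)cc3)c(C)c(O)c2c1` gives 1.23% in this assay. Compound 3 `CCc1ccc2nc(C(=O)Nc3c(F)cc(-c4cccc(F)c4)cc3F)c(C)c(C(=O)O)c2c1` gives 0% in this assay. Compound 3 arises from compound 1 by a single change, (carboxy in place of hydroxy on an aromatic carbon), and this change produced a number 5.6 percentage points lower from compound 1 to compound 3 (within the scatter). The difference between the cores of compound 1 and compound 2 is not broken down here.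

Compound 4 `COc1ccc2nc(C(=O)Nc3ccc(-c4ccccc4)cc3)c(C)c(C(=O)O)c2c1` has not yet been measured. It arises from compound 2 by the same change, (carboxy in place of hydroxy on an aromatic carbon), made at a place described in exactly the same words as in the earlier pair. Going by the values given here, the only guide to what this change does is the earlier pair, where the step from compound 1 to compound 3 stayed within the usual scatter of this assay. On that basis the step from compound 2 to compound 4 is expected to be a number 0.7 percentage points lower from compound 2 to compound 4 (within the scatter), and, since compound 2 already sits near the bottom of the read-out, compound 4 is estimated to give 0.5% in this assay, with a plausible range from 0% to 8%.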

Compound 4, a percentage reported as inhibition, at one concentration (the size of the read-out at that concentration, not a potency): 0.65%
Compound 4: the middle estimate sits 0.2 percentage points below what was measured; the range from low to high includes it.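

Replacing hydroxy with carboxy in this assay gives a number 0.6 percentage points lower from compound 2 to compound 4 (within the scatter). Set beside the earlier step, the change reads alike on the two cores: the same change on two cores in this assay, a number 5.6 percentage points lower (within the scatter) from compound 1 to compound 3 and a number 0.6 percentage points lower (within the scatter) from compound 2 to compound 4, 5 percentage points apart, within the scatter of two such steps All four compounds give small numbers at this single concentration, so the agreement shows only that the change makes no readable difference on either core, and it does not show that the change would stay as quiet on a compound with a much larger reading, nor does it say anything about potency.

The compounds shown leave open what a different group at this same place, such as an amine or a nitrile, would do to the reading. They also leave open what each separate difference between the cores of compound 1 and compound 2 contributes, and whether a longer chain in place of the methyl group would alter the picture.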